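Dropping the Methoxy Group from Compound 2

The compounds below may be only part of what the source reports. "The series", "measured", "known", "first", "only" and "open" are said of these compounds alone.

Three related compounds have been measured in a functional assay on SF-268 cells (Homo sapiens) for inhibition, read by sulforhodamine B assay, with a stated time of 48 h; a higher number here means a weaker inhibitor of growth, a lower number a stronger inhibitor of growth. Compound 1 `N=C(N)c1ccc(-c2ccc(-c3cc(Cl)cc(Cl)c3)s2)s1` gives 1960 nM. Compound 2 `COc1ccc(-c2ccc(-c3ccc(C(=N)N)o3)o2)cc1` gives 2040 nM, and compound 3 `COc1cc(OC)cc(-c2ccc(-c3ccc(C(=N)N)o3)o2)c1` gives 3400 nM. Compound 2 thus sits at the second highest number of the three, close to compound 1 and somewhat apart from compound 3, though both gaps fall within the usual scatter. Compound 4 `N=C(N)c1ccc(-c2ccc(-c3ccccc3)o2)o1` has not yet been measured; it differs from compound 2 by hydrogen in place of methoxy on an aromatic carbon. Going by the values given here, no step between measured compounds isolates this change, so the direction is uncertain; an expected step of a 1.2-fold higher number from compound 2 to compound 4 (0.09 log units; within the scatter) from compound 2 to compound 4 is taken to lie within the scatter. Compound 4 is estimated at 2500 nM in this assay, with a range from 1000 nM to 6000 nM.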

Compound 4, concentration for 50% growth inhibition: 2980 nM
The estimate for compound 4 lay 1.2-fold (0.08 log units) below the measured number; the range from low to high includes it.
By their numbers in this assay, from the lowest: compounds 1, 2, 4 and 3 (each within the scatter of the next).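

Going by these compounds alone, the step from methoxy to hydrogen gives the first direct reading of this change in this assay: a 1.5-fold higher number from compound 2 to compound 4 (0.16 log units; within the scatter). At this place on the six-membered aromatic ring, para to a large group, the methoxy group can therefore be removed with no difference beyond the scatter. No accompanying measurement explains this result.

From the compounds shown here alone, it remains open whether another group at this place, such as an amine or a carboxylic acid, would shift the number beyond the scatter. The same question stands for this change on the core of compound 1.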